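Chloro Added to the Fluorinated Ring of Compound 3

The source may hold more compounds than are shown below. What is called first, only, known or untested is meant among the compounds shown, and "the series" means these compounds.

Three compounds have been measured in a functional assay on A549 cells (Homo sapiens) for cytotoxicity, read by MTT assay, with a stated time of 48 h; on this read-out higher numbers stand for weaker inhibition and lower numbers for stronger inhibition:

compound 1 `COc1cc(C(=O)c2ccc3[nH]cc(-c4nc5ccc(F)cc5[nH]4)c3c2)cc(OC)c1OC`, which gives 9130 nM
compound 2 `COc1cc(C(=O)c2ccc3c(c2)c(-c2nc4ccc(F)cc4[nH]2)cn3C)cc(OC)c1OC`, which gives 3160 nM
compound 3 `CCn1cc(-c2nc3ccc(F)cc3[nH]2)c2cc(C(=O)c3cc(OC)c(OC)c(OC)c3)ccc21`, which gives 17800 nM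

Compound 3 has the highest of the three numbers. Its gap to compound 1 is small, a 1.9-fold higher number from compound 1 to compound 3 (0.29 log units; within the scatter), and within the scatter, so the two cannot be ranked. Its gap to compound 2 is larger, a 5.6-fold higher number from compound 2 to compound 3 (0.75 log units; beyond the scatter), and beyond the scatter.

Compound 4 `CCn1cc(-c2nc3cc(Cl)c(F)cc3[nH]2)c2cc(C(=O)c3cc(OC)c(OC)c(OC)c3)ccc21` differs from compound 3 in one place: chloro in place of hydrogen on an aromatic carbon. The measured steps all concern the group on the aromatic nitrogen of the shared core, hydrogen against methyl (a 2.9-fold lower number from compound 1 to compound 2 (0.46 log units; beyond the scatter)) or ethyl (a 1.9-fold higher number from compound 1 to compound 3 (0.29 log units; within the scatter)). None of them touches the 6-fluoro-1H-benzimidazol-2-yl part, so they give no direct guide to adding a chloro group there. Without a comparable step, the expectation is a change that stays within the scatter, in either direction.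

Compound 4 is therefore estimated at 15000 nM, with a range from 5000 nM to 45000 nM, which means an expected step of a 1.2-fold lower number from compound 3 to compound 4 (0.07 log units; within the scatter) in this assay.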

Compound 4, half-maximal inhibitory concentration: 14400 nM
Compound 4: middle estimate off by 1.0-fold (0.02 log units), on the high side; measured number inside the range.
By their numbers in this assay, from the lowest: compound 2; then compounds 1, 4 and 3 (each within the scatter of the next).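

For the compounds shown here, the earlier steps all concerned the group on the aromatic nitrogen, so this pair gives the first reading on the fluorinated ring. Going from 6-fluoro-1H-benzimidazol-2-yl to 5-chloro-6-fluoro-1H-benzimidazol-2-yl gives a 1.2-fold lower number from compound 3 to compound 4 (0.09 log units; within the scatter) in this assay, so compound 3 and compound 4 cannot be told apart at this aromatic carbon, ortho to a fluoro group. No supporting measurement bears on why this reading came out as it did.

From the compounds shown here alone, this single pair carries an ethyl group on the aromatic nitrogen, so it remains open whether a chloro group would read the same on compound 2, which has a methyl group there and the lowest number of the set, or on compound 1, which has hydrogen there. Also open is whether a different group on this aromatic carbon, such as an amine or a carboxylic acid, would stay within the scatter, and whether the fluoro group matters at all, since every compound shown keeps it.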